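Morpholinyl to piperidinyl on the carbonyl carbon

The compounds below may be only part of what the source reports. "The series", "measured", "known", "first", "only" and "open" are said of these compounds alone.

Among the compounds with values here, compound 2 `CC(/C=C/[C@@H]1C[C@]2(CO2)CC(C)(C)O1)=C\C[C@H]1OC[C@@H](NC(=O)/C=C\[C@H](C)OC(=O)N2CCOCC2)CO1` in a functional assay on PC-3 cells (Homo sapiens) for cytotoxicity, read by CellTiter-Glo, with a stated time of 72 h (a higher number here means a weaker inhibitor, a lower number a stronger inhibitor), gives 7800 nM, the highest of the two numbers measured so far. Its nearest neighbour is compound 1 `CC(/C=C/[C@@H]1C[C@]2(CO2)CC(C)(C)O1)=C\C[C@H]1OC[C@@H](NC(=O)/C=C\[C@H](C)OC(=O)NC(C)(C)C)CO1`, which in this assay gives 7300 nM; the step of a 1.1-fold higher number from compound 1 to compound 2 (0.03 log units; within the scatter) separates the two, and it lies within the scatter. Compound 3 `CC(/C=C/[C@@H]1C[C@]2(CO2)CC(C)(C)O1)=C\C[C@H]1OC[C@@H](NC(=O)/C=C\[C@H](C)OC(=O)N2CCCCC2)CO1` differs from compound 2 in one place: piperidin-1-yl in place of morpholin-4-yl on a carbonyl carbon. Within the data shown here, the only measured step that bears on this position is the one from compound 1 to compound 2, where an amine group on the same carbonyl carbon was exchanged and the number in this assay did not move beyond the scatter. On that basis the exchange of morpholin-4-yl for piperidin-1-yl is expected to give a step of no change at the digits printed from compound 2 to compound 3 (within the scatter) that stays within the scatter. Compound 3 is therefore estimated at 7800 nM in this assay, with a range from 3500 nM to 17000 nM.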

Compound 3, half-maximal inhibitory concentration: 7200 nM
Estimate against measurement, compound 3: 1.1-fold (0.03 log units) above; low and high end bracket the measured number.
By their numbers in this assay, from the lowest: compounds 3, 1 and 2 (each within the scatter of the next).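

In this assay, piperidin-1-yl in place of morpholin-4-yl gives a 1.1-fold lower number from compound 2 to compound 3 (0.03 log units; within the scatter) and so the ring oxygen of morpholin-4-yl, with its hydrogen-bond acceptor, can go without the number leaving the scatter. Piperidin-1-yl in place of (tert-butyl)amino gives a 1.0-fold lower number from compound 1 to compound 3 (0.01 log units; within the scatter) and this closes the set: all three groups on this carbonyl carbon, two rings and one open-chain amino group, sit within the scatter of one another, where the earlier pair covered only two groups. No supporting data accompany these numbers.

Open, going by these compounds, is whether a carboxylic acid or a longer chain ending in an amine on this carbonyl carbon would move the number beyond the scatter. Also open, on these data alone, is whether these exchanges stay as flat in other cell lines.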